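Working notes: anilino to 4-methylpiperidin-1-yl on compound 1

The source may hold more compounds than are shown below. What is called first, only, known or untested is meant among the compounds shown, and "the series" means these compounds.

compound 1 `Nc1ccccc1NC(=O)/C=C/c1ccc(Cn2cnc3c(Nc4ccccc4)nc(Cl)nc32)cc1` — 16.4%
compound 2 `Nc1ccccc1NC(=O)c1ccc(Cn2cnc3c(Nc4ccccc4)nc(Cl)nc32)cc1` — 49.6%
compound 3 `Nc1ccccc1NC(=O)c1ccc(CNc2nc(Cl)nc3c2ncn3Cc2ccccc2)cc1` — 5.01%

All three were run in a functional assay on HepG2 cells (Homo sapiens) for antiproliferative activity, read by CCK-8 assay, with a stated time of 72 h, tested at 2 uM; on this read-out lower numbers stand for a weaker effect and higher numbers for a stronger effect at the one concentration tested. Compound 1 stands second highest of the three: compound 3 lies somewhat lower, beyond the scatter, and compound 2 lies well above. Going by the values given here, the only single-place step measured, a number 33.2 percentage points higher from compound 1 to compound 2 (beyond the scatter), concerns the amide linker, not the position changed here. On these data alone, compound 4 `CC1CCN(c2nc(Cl)nc3c2ncn3Cc2ccc(/C=C/C(=O)Nc3ccccc3N)cc2)CC1` is untested. Among the compounds with values here, it differs from compound 1 in one place: 4-methylpiperidin-1-yl in place of anilino on an aromatic carbon No measured step touches that position, and compounds 1 and 3 differ in more than one place, so no single-point comparison exists for it. With nothing to rest on, compound 4 is expected to sit near compound 1, a number 1.6 percentage points higher from compound 1 to compound 4 (within the scatter), within the scatter. The estimate for compound 4 is 18%, range 4% to 40%.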

Compound 4, a percentage reported as inhibition, at one concentration (the size of the read-out at that concentration, not a potency): 8.73%
Compound 4: the middle estimate sits 9.3 percentage points above what was measured; the measured number falls inside the stated range.
By their numbers in this assay, from the lowest: compounds 3, 4 and 1 (each within the scatter of the next, the first and the last beyond it); then compound 2.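

In this assay, putting 4-methylpiperidin-1-yl in place of anilino gives a number 7.7 percentage points lower from compound 1 to compound 4 (within the scatter), so this change, from an aromatic ring of carbon only to a non-aromatic ring with one fewer hydrogen-bond donor, does not separate the two compounds. This holds only alongside the 2-((2-aminophenyl)carbamoyl)ethenyl group. No measurement at hand explains this reading.

On these data alone, it remains open whether the same swap would read alike with the (2-aminophenyl)carbamoyl group of compound 2. As far as these compounds go, how a morpholin-4-yl or dimethylamino group would read at this position also remains open.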